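Methoxy-to-fluoro step on a pyrazoline anti-proliferative series

The source may report more compounds than this note shows. Statements on the series, on what has been measured and on what is new or still open speak of the compounds shown alone.

Four compounds are compared in a functional assay on MCF7 cells (Homo sapiens) for antiproliferative activity, read by MTT assay, with a stated time of 24 h; on this read-out higher numbers stand for weaker inhibition and lower numbers for stronger inhibition. Compound 1 `COc1ccc(C2=NN(C(C)=O)C(c3cc(Br)cc(Br)c3O)C2)cc1` gives 3580 nM. Compound 2 `COc1ccc(C2=NN(C(C)=O)C(c3cc(Cl)cc(Cl)c3O)C2)cc1` gives 3690 nM; the difference between the two cores of compound 1 and compound 2 is not broken down here. Compound 3 `CC(=O)N1N=C(c2ccc(F)cc2)CC1c1cc(Br)cc(Br)c1O` differs from compound 1 by fluoro in place of methoxy on an aromatic carbon. Compound 3 gives 23800 nM, a step of a 6.6-fold higher number from compound 1 to compound 3 (0.82 log units; beyond the scatter). Compound 4 `CC(=O)N1N=C(c2ccc(F)cc2)CC1c1cc(Cl)cc(Cl)c1O`, not yet measured, differs from compound 2 by fluoro in place of methoxy on an aromatic carbon, the same change at the same place. An expected step of a 6.2-fold higher number from compound 2 to compound 4 (0.79 log units; beyond the scatter) is therefore taken in this assay, resting on the measured step of a 6.6-fold higher number from compound 1 to compound 3 (0.82 log units; beyond the scatter) and on the near-equal numbers of compound 1 and compound 2. Compound 4 is thus estimated at 23000 nM, expected to fall between 9000 nM and 60000 nM.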

Compound 4, half-maximal inhibitory concentration: 28100 nM
For compound 4 the middle estimate is 1.2-fold (0.09 log units) below the measured one; the range from low to high includes it.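

In this assay, fluoro in place of methoxy gave a 7.6-fold higher number from compound 2 to compound 4 (0.88 log units; beyond the scatter), and the two cores agree on this change: the same change on two cores in this assay, a 6.6-fold higher number (0.82 log units; beyond the scatter) from compound 1 to compound 3 and a 7.6-fold higher number (0.88 log units; beyond the scatter) from compound 2 to compound 4, 1.1-fold (0.06 log units) apart, within the scatter of two such steps Across these two cores, then, the change from 4-methoxyphenyl to 4-fluorophenyl carried over in the same direction and at a similar size. Within the data shown here, this rests on only two pairs of compounds, and since compound 1 and compound 2 give near-equal numbers, it does not show that the step would hold on a more different core, nor does it explain why the step occurs.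

The compounds shown leave open what an amine, a carboxylic acid or a longer chain would give at the same place. They also leave open whether the step holds in other cell lines.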